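This account rests on a few compounds, and the source may have more. Where it says the series, first, only, none or still open, it means among the compounds named here.

Working notes on the series, read in a physicochemical assay for lipophilicity, measured as octanol-water partition, at pH 7.4; on this read-out higher numbers stand for higher lipophilicity and lower numbers for lower lipophilicity. Compound 1 (`Cc1ccc2[nH]c(C(=O)N[C@H]3CN(S(=O)(=O)c4cnccn4)C[C@@H]3C(=O)NCCN(C)C)cc2c1`) gives 1, and compound 2 (`Cc1ccc2[nH]c(C(=O)N[C@H]3CCN(S(=O)(=O)N4CCCCC4)C[C@@H]3C(=O)NCCN(C)C)cc2c1`) gives 2.3. Compound 3 (`Cc1ccc2[nH]c(C(=O)N[C@H]3CN(S(=O)(=O)c4ccccc4)C[C@@H]3C(=O)NC[C@H]3CCCN3)cc2c1`) gives 1, level with compound 1 within the scatter. These two share the lowest reading of the three, and compound 2 stands clearly higher than both.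

The next compound is compound 4 (`Cc1ccc2[nH]c(C(=O)N[C@H]3CN(S(=O)(=O)c4ccccc4)C[C@@H]3C(=O)N[C@@H]3CCCN(C)C3)cc2c1`), which carries 1-methylpiperidin-3-yl in place of (pyrrolidin-2-yl)methyl on an amide-type nitrogen.

Among the compounds with values here, no measured pair differs in one place only, so the data give no direct guide to the size of this step. Compound 2 differs from the other two in several places at once and cannot serve as a guide. The expectation in this assay is therefore a small upward step that stays within the scatter, starting from compound 3 at 1. The expected shift is a number 0.30 log units higher from compound 3 to compound 4 (within the scatter). For compound 4 the estimated value is 1.3, with an expected range of 0.7 to 1.9.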

Compound 4, distribution coefficient: 2.7
The estimate for compound 4 lay 1.40 log units below the measured number; the measured number lies above the stated range.
By their numbers in this assay, from the lowest: compounds 1 and 3 (each within the scatter of the next); then compound 2; then compound 4.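

In this assay, within the data shown here, the substituent on the amide-type nitrogen proves able to move the read-out on its own: 1-methylpiperidin-3-yl in place of (pyrrolidin-2-yl)methyl gives a number 1.70 log units higher from compound 3 to compound 4 (beyond the scatter), the only step that isolates one place. The exchange changes several counted features together, with compound 4 carrying more heavy atoms than compound 3, a six-membered non-aromatic ring against a five-membered one, and fewer hydrogen-bond donors, so the step cannot be assigned to any one of them. Nothing available on these compounds accounts for its size.

Going by these compounds, whether the step follows the ring size, the added methyl or the lost donor stays open; piperidin-3-yl or (1-methylpyrrolidin-2-yl)methyl on the same nitrogen would help separate these. On these data alone, whether the exchange gives a similar step with the other sulfonyl groups of compound 1 and compound 2 also stays open.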